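Exchanging cyanophenyl for bromophenyl on compound 2

The compounds below may be only part of what the source reports. "The series", "measured", "known", "first", "only" and "open" are said of these compounds alone.

In a functional assay on Caco-2 cells (Homo sapiens) for cytotoxicity, with a stated time of 48 h (a lower number here means a stronger inhibitor, a higher number a weaker inhibitor), compound 2 `N#Cc1ccc(-c2cc(COC(Cc3cn(C4CCN(Cc5ccc([N+](=O)[O-])cc5)CC4)nn3)c3ccc(Br)cc3)on2)cc1` gives 2000 nM, while compound 1 `O=[N+]([O-])c1ccc(CN2CCC(n3cc(CC(OCc4cc(-c5ccc(Br)cc5)no4)c4ccc(Br)cc4)nn3)CC2)cc1` gives 3000 nM; the two numbers lie within the scatter of each other. Compound 3 `O=[N+]([O-])c1ccc(CN2CCC(n3cc(CC(OCc4cc(-c5cccc(Br)c5)no4)c4ccc(Br)cc4)nn3)CC2)cc1` differs from compound 2 by 3-bromophenyl in place of 4-cyanophenyl on an aromatic carbon. Going by the values given here, the one measured step that bears on this exchange, a 1.5-fold lower number from compound 1 to compound 2 (0.18 log units; within the scatter), also traded bromo against cyano, and on that basis no step beyond the scatter is expected in this assay. Compound 3 is therefore estimated at 2500 nM, with a range from 1200 nM to 5500 nM, an expected step of a 1.3-fold higher number from compound 2 to compound 3 (0.10 log units; within the scatter).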

Compound 3, half-maximal inhibitory concentration: 5000 nM
For compound 3 the middle estimate is 2.0-fold (0.30 log units) below the measured one; the range from low to high includes it.
By their numbers in this assay, from the lowest: compounds 2, 1 and 3 (each within the scatter of the next, the first and the last beyond it).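

In this assay this aromatic carbon of the five-membered ring gives the only step beyond the scatter among these compounds, where 3-bromophenyl replaces 4-cyanophenyl (a 2.5-fold higher number from compound 2 to compound 3 (0.40 log units; beyond the scatter)). The two bromophenyl compounds remain within the scatter of each other (a 1.7-fold higher number from compound 1 to compound 3 (0.22 log units; within the scatter)), so moving the bromine around the phenyl ring does not register on its own here. Nothing measured here accounts for either step. Still open, going by these compounds, is how an amine or a carboxylic acid on this phenyl ring would read, and whether 3-cyanophenyl would match 4-cyanophenyl.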